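Removing one chloro from compound 3

The source may report more compounds than this note shows. Statements on the series, on what has been measured and on what is new or still open speak of the compounds shown alone.

The shared core carries an anilino group whose para-substituted ring varies across the set. Compound 1 `Fc1ccc(Nc2ccc(N3CC4CC(C3)N4)nn2)cc1` gives 868 nM in an assay on cell membranes for displacement of a labelled ligand from Neuronal acetylcholine receptor; alpha4/beta2 (Rattus norvegicus); on this read-out lower numbers stand for stronger inhibition and higher numbers for weaker inhibition. Among the measured compounds shown here, compound 2 `O=[N+]([O-])c1ccc(Nc2ccc(N3CC4CC(C3)N4)nn2)cc1` gives 86.2 nM, and the step of a 10-fold lower number from compound 1 to compound 2 (1.00 log units; beyond the scatter) is the only single-point change measured here. Compound 3 `Clc1ccc(Nc2ccc(N3CC4CC(C3)N4)nn2)cc1Cl` gives 516 nM; its number is second highest of the three, closest to compound 1 and furthest from compound 2, which sits well below it.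

Compound 4 `Clc1ccc(Nc2ccc(N3CC4CC(C3)N4)nn2)cc1` differs from compound 3 by hydrogen in place of chloro on an aromatic carbon. For the measured compounds named here, no measured step removes a chloro, so the only step on record, which exchanges a fluoro for a nitro, does not bear directly on this change. With the halogen-bearing analogues compound 1 and compound 3 already close together, compound 4 is expected to stay near them, with a step of a 1.3-fold higher number from compound 3 to compound 4 (0.10 log units; within the scatter) that is not expected to exceed the scatter. Compound 4 is therefore estimated at 650 nM, within a range from 250 nM to 1700 nM.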

Compound 4, inhibition constant: 90.4 nM
For compound 4 the middle estimate is 7.2-fold (0.86 log units) above the measured one; the measured number lies below the stated range.
By their numbers in this assay, from the lowest: compounds 2 and 4 (each within the scatter of the next); then compounds 3 and 1 (each within the scatter of the next).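

Removing this chloro, which sits ortho to a chloro group and meta to a large group, is not a neutral change in this assay: the step is a 5.7-fold lower number from compound 3 to compound 4 (0.76 log units; beyond the scatter), so the added chloro of compound 3 weakens binding relative to compound 4. The identity of the remaining ring substituent also matters, since chloro in place of fluoro gives a 9.6-fold lower number from compound 1 to compound 4 (0.98 log units; beyond the scatter), whereas chloro in place of nitro gives a 1.0-fold higher number from compound 2 to compound 4 (0.02 log units; within the scatter) and leaves those two compounds indistinguishable. Nothing shown here gives a reason for these steps.

The compounds shown leave open whether only chloro is disfavoured at this position or whether a methyl or methoxy group there would give a similar step. They also leave open whether an amine or a nitrile in place of the fluoro of compound 1 would match compound 2 and compound 4.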